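Methoxy to methyl step carried across two cores

The source may hold more compounds than are shown below. What is called first, only, known or untested is meant among the compounds shown, and "the series" means these compounds.

Compound 1 `COc1ccc(C2=NO[C@]3(C2)C(=O)O[C@@H]2[C@H]3CC[C@H](C)[C@]3(O)C=CC(=O)[C@@]23C)cc1` and compound 2 `Cc1ccc(C2=NO[C@]3(C2)C(=O)O[C@@H]2[C@H]3CC[C@H](C)[C@]3(O)C=CC(=O)[C@@]23C)cc1` share one core; compound 2 carries the change (methyl in place of methoxy on an aromatic carbon). In a physicochemical assay for lipophilicity (on this read-out lower numbers stand for lower lipophilicity and higher numbers for higher lipophilicity), compound 1 gives 1.47, and compound 2 gives 1.86. The step of a number 0.39 log units higher from compound 1 to compound 2 (beyond the scatter) lies beyond the usual scatter of this measurement. Compound 3 `COc1ccc(C2C[C@@]3(ON2c2ccccc2)C(=O)O[C@@H]2[C@H]3CC[C@H](C)[C@]3(O)C=CC(=O)[C@@]23C)cc1` stands on a second core; how the core of compound 3 differs from the core of compound 1 is not broken down here. In this assay compound 3 gives 3.25, the highest of the three measured numbers, beyond the scatter from both compound 2 and compound 1. Compound 4 `Cc1ccc(C2C[C@@]3(ON2c2ccccc2)C(=O)O[C@@H]2[C@H]3CC[C@H](C)[C@]3(O)C=CC(=O)[C@@]23C)cc1` is not yet measured; it differs from compound 3 by methyl in place of methoxy on an aromatic carbon, which is the same change as that between compound 1 and compound 2, at a place described in the same words. Compound 4 is expected to show a step of a number 0.39 log units higher from compound 3 to compound 4 (beyond the scatter) in this assay. Among the compounds with values here, this expectation rests on the single measured example of the change, the step of a number 0.39 log units higher from compound 1 to compound 2 (beyond the scatter). Compound 4 is therefore estimated at 3.64 in this assay, with a range from 3.3 to 4.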

Compound 4, partition coefficient: 3.64
Compound 4: middle estimate and measured number agree at the digits printed, and the stated range covers the measured number.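

In this assay, methyl in place of methoxy on an aromatic carbon gives a number 0.39 log units higher from compound 3 to compound 4 (beyond the scatter) on the second core, and the same change on the first core gives a number 0.39 log units higher from compound 1 to compound 2 (beyond the scatter), so the step has the same printed size on both cores. This shows that the 4-methoxyphenyl to 4-methylphenyl change carried over between these two cores in this read-out, but two pairs do not show that it would hold on any further core in the series or in any other read-out. No measurement at hand bears on what sets the size of the step or on what lies behind its match between the two cores.

The compounds shown leave open whether a different group at the same place, such as an amine, a carboxylic acid or a longer chain, would also give one step across both cores. They also leave open whether methyl in place of methoxy gives this step elsewhere on the six-membered aromatic ring.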